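A bromo-to-methoxy swap on the aryl group

The compounds below may be only part of what the source reports. "The series", "measured", "known", "first", "only" and "open" are said of these compounds alone.

In a functional assay on MCF7 cells (Homo sapiens) for inhibition, read by sulforhodamine B assay, with a stated time of 72 h (a higher number here means a weaker inhibitor, a lower number a stronger inhibitor), compound 2 (`COc1ccc2cc(C(C)c3nnc4n3N=C(c3ccc(Br)cc3)CS4)ccc2c1`) gives 11500 nM and stands level, within the scatter, with compound 1 (`COc1ccc2cc(C(C)c3nnc4n3N=C(c3ccc([N+](=O)[O-])cc3)CS4)ccc2c1`) at 18800 nM on the same scale. Compound 3 (`COc1ccc(C2=Nn3c(nnc3C(C)c3ccc(-c4ccccc4)c(F)c3)SC2)cc1`) gives 2600 nM as a number lower than that of compound 2 by more than the scatter.

Compound 4 (`COc1ccc(C2=Nn3c(nnc3C(C)c3ccc4cc(OC)ccc4c3)SC2)cc1`) differs from compound 2 in one place (methoxy in place of bromo on an aromatic carbon) with methoxy in place of bromo on an aromatic carbon, so that 4-bromophenyl becomes 4-methoxyphenyl. Going by the values given here, the one measured step at this same substituent is bromo in place of nitro (a 1.6-fold lower number from compound 1 to compound 2 (0.21 log units; within the scatter)) and it stays within the scatter. Among the compounds with values here, no measured pair isolates methoxy itself. Compound 3 does carry 4-methoxyphenyl, but it also differs from compound 2 elsewhere, so its number cannot be credited to that group alone.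

In this assay no step beyond the scatter is therefore expected (a 1.3-fold lower number from compound 2 to compound 4 (0.11 log units; within the scatter)) and the slight lean toward a lower number is only a tentative expectation, resting on compound 3 (2600 nM) as the one measured carrier of 4-methoxyphenyl. Compound 4 is estimated at 9000 nM within an expected range (3500 nM to 22000 nM).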

Compound 4, half-maximal inhibitory concentration: 6600 nM
Compound 4: middle estimate off by 1.4-fold (0.13 log units), on the high side; the measured number falls inside the stated range.
By their numbers in this assay, from the lowest: compound 3; then compounds 4, 2 and 1 (each within the scatter of the next, the first and the last beyond it).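

Going by these compounds alone, with the rest of the molecule held constant, compound 4 gives the first direct reading of methoxy on this aromatic carbon in this assay: the change from bromo gives a 1.7-fold lower number from compound 2 to compound 4 (0.24 log units; within the scatter), so this swap does not separate the two compounds. Methoxy in place of nitro at the same position gives a 2.8-fold lower number from compound 1 to compound 4 (0.45 log units; beyond the scatter), a modest step and the only one among these three substituents that clears the scatter, while compound 2 remains within the scatter of both compound 1 and compound 4. Nothing measured here speaks to what lies behind these steps.

From the compounds shown here alone, the three groups at this position span only a narrow range of numbers, so it remains open whether an amine, a carboxylic acid or a longer chain such as butoxy in the same place would give a step clearly beyond the scatter. Compound 3 also carries 4-methoxyphenyl and gives 2600 nM, but the compounds shown include no series that tests how far changes at the other end of the molecule would carry over to the substituents compared here.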